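Piperidinyl to diisopropylamino on the propoxy chain

The source may report more compounds than this note shows. Statements on the series, on what has been measured and on what is new or still open speak of the compounds shown alone.

Measured compounds:
compound 1 `CC(=O)Oc1ccc(C(=O)Nc2cc3ccc(OCC4CCCNC4)c(C)c3oc2=O)cc1CC=C(C)C`: 620 nM
compound 2 `CC(C)=CCc1cc(C(=O)Nc2cc3ccc(OCCCN4CCCCC4)c(C)c3oc2=O)ccc1O`: > 50000 nM

In a functional assay on SK-BR-3 cells (Homo sapiens) for antiproliferative activity (on this read-out higher numbers stand for weaker inhibition and lower numbers for stronger inhibition), compound 1 gives 620 nM. Compound 2 sits at the limit of > 50000 nM in this assay, at which 1 of the 2 values shown sits, so for compound 2 the read-out is a limit and not a number. Compound 3 `CC(C)=CCc1cc(C(=O)Nc2cc3ccc(OCCCN(C(C)C)C(C)C)c(C)c3oc2=O)ccc1O` differs from compound 2 in one place: diisopropylamino in place of piperidin-1-yl on a saturated chain carbon, three bonds along the chain from an oxygen on an aromatic ring. Going by the values given here, no step between measured compounds is available to gauge this change, so no shift beyond the scatter is expected either way, and the estimate is understood to be guided by the limit of compound 2. The step from compound 2 to compound 3 is expected to be about an at least 1.2-fold lower number from compound 2 to compound 3 (0.09 log units; that floor lies within the scatter). Compound 3 is estimated at 40000 nM, with a range from 10000 nM to 100000 nM.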

Compound 3, half-maximal inhibitory concentration: 1600 nM
For compound 3 the middle estimate is 25-fold (1.40 log units) above the measured one, and the stated range ends above it.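

Going by these compounds alone, at the end of this chain, on a saturated carbon three bonds from the oxygen on the aromatic ring, the earlier compounds offered no step to judge by. In this assay, diisopropylamino in place of piperidin-1-yl now shows that the group here can carry a large shift, with an at least 31-fold lower number from compound 2 to compound 3 (1.49 log units; beyond the scatter). That size is only a floor, since compound 2 stands at a limit of the assay: the limit of > 50000 nM in this assay, at which 1 of the 3 values shown sits.

Still open, as far as these compounds go, is how a dimethylamino or morpholin-4-yl group would compare at this place, and whether a longer chain would keep the activity of compound 3.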